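The source may hold more compounds than are shown below. What is called first, only, known or untested is meant among the compounds shown, and "the series" means these compounds.

Compound 1 `O/N=C(/Nc1ccccc1)c1ccc2occc2c1` is the smallest member of the series. In an assay on isolated protein for inhibition of Indoleamine 2,3-dioxygenase 1 (Homo sapiens), read by spectrophotometry (a higher number here means a weaker inhibitor, a lower number a stronger inhibitor), compound 1 gives > 30000 nM, which is a limit of the assay and not a number. Compound 2 `O=C(NCc1ccccc1)c1cccc(N/C(=N/O)c2ccc3occc3c2)c1` extends the shared core by an amide bearing a benzylamino group. In this assay compound 2 gives > 30000 nM, again a limit rather than a measured value. Both values shown sit at the same edge of the assay (the limit of > 30000 nM in this assay, at which 2 of the 2 values shown sit), so compound 2 stands level with compound 1 at the boundary of what can be reported. Compound 3 `CC1CCN(C(=O)c2cccc(N/C(=N/O)c3ccc4occc4c3)c2)CC1` differs from compound 2 by 4-methylpiperidin-1-yl in place of benzylamino on a carbonyl carbon. Going by the values given here, no measured pair shows a step of this kind, so its size is unknown. Given the limit for compound 2, the expected step is a step that the limit leaves unreadable from compound 2 to compound 3, none beyond the scatter. Compound 3 is therefore expected to give about 40000 nM in this assay, within 10000 nM to 150000 nM, most likely reported once more as a limit.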

Compound 3, half-maximal inhibitory concentration: > 30000 nM
Compound 3 was reported as a limit (the forecaster's own chance of this, stated with the estimate: 75%); the middle value does not contradict the limit.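

No step can be read from compound 1 or compound 2 to compound 3, since all three values are limits of the assay and not numbers: the limit of > 30000 nM in this assay, at which 3 of the 3 values shown sit. The compounds shown leave open whether 4-methylpiperidin-1-yl in place of benzylamino on a carbonyl carbon changes inhibition at all, and what any of the three actual potencies is.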